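A Methoxybenzyl Change in Place of Methylbenzyl

A few compounds are considered here, and "the series" means these few. Any claim that something is new, unique, unknown or untested is made for them only; others in the source may bear on it.

In a functional assay on Jurkat cells (Homo sapiens) for inhibition, read by CCK-8 assay, with a stated time of 48 h (a higher number here means a weaker inhibitor of growth, a lower number a stronger inhibitor of growth), compound 1 (`Cc1ccccc1Nc1nc(Nc2ccc(N3CCN(C)CC3)cn2)ncc1Cl`) gives 8080 nM and compound 3 (`Cc1ccc(CNc2nc(Nc3ccc(N4CCN(C)CC4)cn3)ncc2Cl)cc1`) gives 12700 nM as two values within the scatter of each other (a 1.6-fold higher number from compound 1 to compound 3 (0.20 log units; within the scatter)). Compound 2 (`CN1CCN(c2ccc(Nc3ncc(Cl)c(NCc4ccccc4)n3)nc2)CC1`) gives > 100000 nM as a limit of the assay and not a number. Compound 4 (`COc1ccccc1CNc1nc(Nc2ccc(N3CCN(C)CC3)cn2)ncc1Cl`) differs from compound 3 by 2-methoxyphenyl in place of 4-methylphenyl on a saturated chain carbon bound to a nitrogen on an aromatic ring with 2-methoxyphenyl in place of 4-methylphenyl on a saturated chain carbon bound to a nitrogen on an aromatic ring. Two measured steps at this place are large or at least modest (an at least 12-fold higher number from compound 1 to compound 2 (1.09 log units; beyond the scatter)) (an at least 7.8-fold lower number from compound 2 to compound 3 (0.89 log units; beyond the scatter)). Compound 3 at 12700 nM is still the closest model for compound 4. A step within the scatter is therefore expected (a 1.2-fold higher number from compound 3 to compound 4 (0.07 log units; within the scatter)). Compound 4 is estimated at 15000 nM with an expected range from 5000 nM to 70000 nM in this assay.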

Compound 4, concentration for 50% growth inhibition: 10800 nM
Compound 4: the middle estimate sits 1.4-fold (0.14 log units) above what was measured; measured number inside the range.
By their numbers in this assay, from the lowest: compounds 1, 4 and 3 (each within the scatter of the next). At a limit, above all of these: compound 2.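

In this assay, 2-methoxyphenyl serves as well as 4-methylphenyl at this place, with a 1.2-fold lower number from compound 3 to compound 4 (0.07 log units; within the scatter), and compound 4 also stays level with the 2-methylphenyl compound, with a 1.3-fold higher number from compound 1 to compound 4 (0.13 log units; within the scatter). Methoxy in place of hydrogen on compound 2 gives an at least 9.2-fold lower number from compound 2 to compound 4 (0.96 log units; beyond the scatter), so a second group besides methyl restores measurable growth inhibition. The value of compound 2 is a limit of the assay and not a number: the limit of > 100000 nM in this assay, at which 1 of the 4 values shown sits.

From the compounds shown here alone, compound 3 and compound 4 differ in both the group and its place on the ring, so which of the two matters remains open. Going by these compounds, whether a chlorine, a hydroxyl or an amine on that ring would serve likewise also remains open.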